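A few compounds are considered here, and "the series" means these few. Any claim that something is new, unique, unknown or untested is made for them only; others in the source may bear on it.

Measured in a functional assay on cells (Platelet, Homo sapiens) for inhibition; a higher number here means a weaker inhibitor, a lower number a stronger inhibitor:
Compound 1 `CC(C)OC(=O)c1ccc(-c2nn(Cc3ccccc3)c3ccccc23)cc1`: > 10000 nM
Compound 2 `NC(=O)c1ccc(-c2nn(Cc3ccccc3)c3ccccc23)cc1`: > 10000 nM

Both entries are limits, not numbers. Compound 2 therefore stands only at its limit of > 10000 nM. Going by the values given here, the one measured step is a step that the two limits leave unreadable from compound 1 to compound 2, and the evidence amounts to the limit of > 10000 nM in this assay, at which 2 of the 2 values shown sit. Compound 3 `CCNC(=O)c1ccc(-c2nn(Cc3ccccc3)c3ccccc23)cc1` follows from ethyl in place of hydrogen on an amide-type nitrogen, with ethyl in place of hydrogen on an amide-type nitrogen. Among the compounds with values here, no measured step gives a size or direction for this change, so no shift beyond the scatter is expected in this assay, and the expected step is a number no higher from compound 2 to compound 3 (the limit leaves the size open). For compound 3 the estimated value is 10000 nM, with an expected range of 3000 nM to 30000 nM.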

Compound 3, half-maximal inhibitory concentration: 5640 nM
Estimate against measurement, compound 3: 1.8-fold (0.25 log units) above; low and high end bracket the measured number.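

Ethyl in place of hydrogen on the amide-type nitrogen gives the first reading in this assay that is a number and not a limit, with an at least 1.7-fold lower number from compound 2 to compound 3 (0.24 log units; that floor lies within the scatter). Ethylamino in place of isopropoxy on the carbonyl carbon reads the same way, with an at least 1.7-fold lower number from compound 1 to compound 3 (0.24 log units; that floor lies within the scatter). Both floors lie within the scatter, and the step between the two compounds held at the limit cannot be read: the limit of > 10000 nM in this assay, at which 2 of the 3 values shown sit.

Open, as far as these compounds go, is how a longer chain such as propyl or butyl on this nitrogen would read. Also open, from the compounds shown here alone, is how a carboxylic acid on the carbonyl carbon would read.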